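Fluoro step from compound 3 to compound 4

A few compounds are considered here, and "the series" means these few. Any claim that something is new, unique, unknown or untested is made for them only; others in the source may bear on it.

In a functional assay on MDA-MB-436 cells (Homo sapiens) for antiproliferative activity, read by MTT assay, with a stated time of 24 h (on this read-out higher numbers stand for weaker inhibition and lower numbers for stronger inhibition), compound 3 `CC(C)(C)c1ccc(C(CC(=O)O)NS(=O)(=O)c2ccccc2)cc1` gives > 100000 nM, which is a limit of the assay and not a number. Compound 1 `O=C(O)CC(NS(=O)(=O)c1ccccc1)c1ccccc1` gives > 100000 nM, also a limit. Compound 2 `O=C(O)CC(NS(=O)(=O)c1ccc(F)cc1)c1ccccc1` gives > 100000 nM, again a limit. Within the data shown here, the series so far shows (the limit of > 100000 nM in this assay, at which 3 of the 3 values shown sit).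

Compound 4 `CC(C)(C)c1ccc(C(CC(=O)O)NS(=O)(=O)c2ccc(F)cc2)cc1` differs from compound 3 in one place: fluoro in place of hydrogen on an aromatic carbon. Among the measured compounds shown here, the closest precedent for this fluoro in place of hydrogen on an aromatic carbon is a step that the two limits leave unreadable from compound 1 to compound 2. The other measured change is a step that the two limits leave unreadable from compound 1 to compound 3. Neither gives a size, so no step beyond the scatter is expected in this assay, in either direction. The expected result is a number no higher from compound 3 to compound 4 (the limit leaves the size open). Compound 4 is estimated at 100000 nM, with an expected range of 40000 nM to 200000 nM.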

Compound 4, half-maximal inhibitory concentration: 68900 nM
For compound 4 the middle estimate is 1.5-fold (0.16 log units) above the measured one; the measured number falls inside the stated range.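

In this assay compound 4 is the first compound shown to give a number rather than a limit, and it carries fluoro and tert-butyl together. The fluoro change gives an at least 1.4-fold lower number from compound 3 to compound 4 (0.16 log units; that floor lies within the scatter) and the tert-butyl change gives an at least 1.4-fold lower number from compound 2 to compound 4 (0.16 log units; that floor lies within the scatter) and both floors lie within the scatter, so neither change is shown to act beyond it. The earlier steps cannot be read, with limits on both sides: the limit of > 100000 nM in this assay, at which 3 of the 4 values shown sit.

As far as these compounds go, whether chloro or methoxy in place of the fluoro would move the number beyond the scatter stays open. So does the effect of a methyl ester in place of the carboxylic acid.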